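One More Methyl on the Chain of Compound 2

The source may hold more compounds than are shown below. What is called first, only, known or untested is meant among the compounds shown, and "the series" means these compounds.

In a functional assay on HCT-116 cells (Homo sapiens) for antiproliferative activity, read by MTT assay, with a stated time of 48 h (on this read-out higher numbers stand for weaker inhibition and lower numbers for stronger inhibition), compound 1 (`CCCCCCC(CCO)n1cnc2c(NC)ncnc21`) reads > 50000 nM, which is a limit and not a number. Within the data shown here, compound 2 (`CCCCCCCC(CCO)n1cnc2c(NC)ncnc21`) gives 12500 nM, the only true number so far. Compound 3 (`CCCCCCCCC(CCO)n1cnc2c(NC)ncnc21`) differs from it by methyl in place of hydrogen on a saturated chain carbon, eight bonds along the chain from an aromatic nitrogen. Among the measured compounds shown here, one measured step bears on this change, the same replacement seven bonds along the chain: an at least 4.0-fold lower number from compound 1 to compound 2 (0.60 log units; beyond the scatter). As far as these compounds go, it rests on (the limit of > 50000 nM in this assay, at which 1 of the 2 values shown sits), so its full size stays open. A further modest drop is expected, and the estimated step is a 2.1-fold lower number from compound 2 to compound 3 (0.32 log units; beyond the scatter). Compound 3 is expected at 6000 nM, with an estimated range of 2000 nM to 18000 nM.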

Compound 3, half-maximal inhibitory concentration: 3730 nM
Estimate against measurement, compound 3: 1.6-fold (0.21 log units) above; measured number inside the range.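

Among these compounds, the step of a 3.4-fold lower number from compound 2 to compound 3 (0.53 log units; beyond the scatter) in this assay is the first at this chain length measured between two true numbers, and it shows that adding a methyl eight bonds along the chain from an aromatic nitrogen still lowers the number, beyond the scatter. Across compounds 1, 2 and 3, none goes against this trend. The ethyl replacement seven bonds along the chain gives an at least 13-fold lower number from compound 1 to compound 3 (1.12 log units; beyond the scatter), but the full size of that step stays open: the limit of > 50000 nM in this assay, at which 1 of the 3 values shown sits.

As far as these compounds go, whether a longer chain would lower the number further, or where the trend would stop, remains open. So does how an amine or a carboxylic acid in place of the methyl would read.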